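This account rests on a few compounds, and the source may have more. Where it says the series, first, only, none or still open, it means among the compounds named here.

Compound 1, with the structure `O=C(Nc1cccc(F)c1)c1cc(=O)[nH]c2cc(Br)ccc12`, is the reference point of this small set. In a functional assay on KYSE-70 cells for antiproliferative activity against KYSE-70 cell line (Homo sapiens), read by MTT assay, with a stated time of 72 h (on this read-out higher numbers stand for weaker inhibition and lower numbers for stronger inhibition), compound 1 gives 8900 nM, and among the two numbers shown this is the lowest, with compound 2 nearest at a difference that stays within the scatter. Compound 2, with the structure `O=C(Nc1cc(F)cc(F)c1)c1cc(=O)[nH]c2cc(Br)ccc12`, gives 10700 nM in this assay, and the change from compound 1 is a 1.2-fold higher number from compound 1 to compound 2 (0.08 log units; within the scatter). Compound 3, with the structure `O=C(Nc1cccc(OC(F)(F)F)c1)c1cc(=O)[nH]c2cc(Br)ccc12`, reaches only a limit of the assay, > 20000 nM in this assay, at which one of the three values shown sits (the limit of > 20000 nM in this assay, at which 1 of the 3 values shown sits). The change from compound 1 to compound 3 is an at least 2.2-fold higher number from compound 1 to compound 3 (0.35 log units; beyond the scatter). The unmeasured compound 4 has the structure `Cc1cc(-c2ccc3c(C(=O)Nc4cccc(F)c4)cc(=O)[nH]c3c2)c(C)cc1F`. Its difference from compound 1 is 4-fluoro-2,5-dimethylphenyl in place of bromo on an aromatic carbon. Neither measured step touches this place: both concern the amide-linked ring, not the bromo on the shared core, so they give no direct guide to the size or direction of the step, and no cause can be assigned. With the reference kept in mind, the step from compound 1 to compound 4 in this assay is expected to be a 3.0-fold lower number from compound 1 to compound 4 (0.47 log units; beyond the scatter), with wide uncertainty. Compound 4 is therefore estimated to give 3000 nM in this assay, within a range from 600 nM to 15000 nM.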

Compound 4, half-maximal inhibitory concentration: > 20000 nM
Compound 4 was reported as a limit (the forecaster's own chance of this, stated with the estimate: 15%); at least 6.6-fold (0.82 log units) between middle value and limit.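

Compound 4 is the first compound shown with a change at the bromo on the shared core, as the earlier steps touched only the amide-linked ring. In this assay, as far as these compounds go, compound 4 reaches a limit of the assay rather than a number: the limit of > 20000 nM in this assay, at which 2 of the 4 values shown sit. Putting 4-fluoro-2,5-dimethylphenyl, which brings a whole aromatic ring of carbon only, in place of bromo gives an at least 2.2-fold higher number from compound 1 to compound 4 (0.35 log units; beyond the scatter), so at this place this group does not hold the inhibition seen with bromo, and how large the loss really is stays unknown.

The compounds shown leave open whether any other replacement for bromo would keep or improve inhibition, for instance a single methyl, an amine, or a plain phenyl ring without the fluoro and the two methyl groups. Among the compounds shown here, they also offer no cause for the loss, and they do not tell whether the same swap would behave alike with a different amide-linked ring, such as the one carrying trifluoromethoxy in compound 3.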